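From methoxy to hydroxy on an aromatic ring

The source may hold more compounds than are shown below. What is called first, only, known or untested is meant among the compounds shown, and "the series" means these compounds.

Compound 1 `Fc1ccc(-c2nnc(SCCCN3CCN(c4nc5ccccc5o4)CC3)o2)cc1`: 136000 nM
Compound 2 `CC(C)(C)Oc1ccc(-c2nnc(SCCCN3CCN(c4nc5ccccc5o4)CC3)o2)cc1`: 65800 nM
Compound 3 `COc1ccc(-c2nnc(SCCCN3CCN(c4nc5ccccc5s4)CC3)o2)cc1`: 56200 nM

All three were tested in a functional assay on A-431 cells (Homo sapiens) for inhibition, read by MTT assay, with a stated time of 72 h; a lower number here means a stronger inhibitor, a higher number a weaker inhibitor. Compound 3, at 56200 nM, lies within the usual scatter of compound 2, while compound 1 has a clearly higher number. The next compound, compound 4 `Oc1ccc(-c2nnc(SCCCN3CCN(c4nc5ccccc5s4)CC3)o2)cc1`, has hydrogen in place of methyl on an oxygen on an aromatic ring, so methoxy becomes hydroxy (hydrogen in place of methyl on an oxygen on an aromatic ring).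

Among the compounds with values here, only one measured step offers any guidance: a 2.1-fold lower number from compound 1 to compound 2 (0.32 log units; beyond the scatter). It is modest, involves tert-butoxy in place of fluoro on an aromatic carbon, and is not the same change. The core of compound 3 also differs from the core of those two compounds. Within the data shown here, no measured pair shows methoxy to hydroxy, so no direction can be argued, and no shift beyond the scatter is expected in this assay. The expected step is a 1.1-fold higher number from compound 3 to compound 4 (0.03 log units; within the scatter). Compound 4 is estimated at 60000 nM, with an expected range of 25000 nM to 140000 nM.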

Compound 4, half-maximal inhibitory concentration: 54700 nM
Compound 4: middle estimate off by 1.1-fold (0.04 log units), on the high side, and the stated range covers the measured number.
By their numbers in this assay, from the lowest: compounds 4, 3 and 2 (each within the scatter of the next); then compound 1.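

Hydroxy in place of methoxy on the 4-methoxyphenyl group is the first change measured at this oxygen, and in this assay it gives a 1.0-fold lower number from compound 3 to compound 4 (0.01 log units; within the scatter). On the core of compound 3, the methyl on this oxygen can therefore be replaced by hydrogen with no shift beyond the scatter, and the swap yields no gain in inhibition of these cells. No measurement available here offers an explanation for this result.

Going by these compounds, it remains open whether a more different group on this aromatic ring, such as an amine, a carboxylic acid or a longer chain on the oxygen, would move the number beyond the scatter. The same swap on the core of compound 1 also remains untested by the compounds shown, so this result cannot be carried over to that core.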